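Swapping the urea's aryl cap for a tert-butyl thiazole

A few compounds are considered here, and "the series" means these few. Any claim that something is new, unique, unknown or untested is made for them only; others in the source may bear on it.

Compound 1 `COc1cccc(NC(=O)Nc2ccc(Nc3ncnc4c3OCCN4)cc2)c1` carries a urea linking a substituted aryl group to a shared core. In an assay on isolated protein for inhibition of proto-oncogene tyrosine-protein kinase receptor Ret (Homo sapiens), read by 33P incorporation, with stated times of 15 min and 40 min (on this read-out higher numbers stand for weaker inhibition and lower numbers for stronger inhibition), compound 1 gives 6810 nM, the highest of the two numbers shown. Compound 2 `O=C(Nc1ccc(Nc2ncnc3c2OCCN3)cc1)Nc1cc(Cl)cc(Cl)c1` gives 865 nM; the step of a 7.9-fold lower number from compound 1 to compound 2 (0.90 log units; beyond the scatter) came with a 3,5-dichlorophenyl in place of 3-methoxyphenyl. Compound 3 `O=C(Nc1ccc(Nc2ncnc3c2OCCN3)cc1)Nc1cccc(-c2ccccc2)c1` gives only a limit, > 10000 nM, and the step of an at least 1.4-fold higher number from compound 1 to compound 3 (0.16 log units; that floor lies within the scatter) cannot be sized beyond that floor (the limit of > 10000 nM in this assay, at which 1 of the 3 values shown sits).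

Compound 4 `CC(C)(C)c1csc(NC(=O)Nc2ccc(Nc3ncnc4c3OCCN4)cc2)n1` is not yet measured. It differs from compound 1 by 4-(tert-butyl)-1,3-thiazol-2-yl in place of 3-methoxyphenyl on an amide-type nitrogen. Neither measured step tries a heteroaromatic cap, so the direction is uncertain; compound 2 shows that changes at this nitrogen can move the number modestly. Compound 4 is expected near 3000 nM, between 600 nM and 15000 nM, a step of a 2.3-fold lower number from compound 1 to compound 4 (0.36 log units; beyond the scatter) that is estimated, not known.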

Compound 4, half-maximal inhibitory concentration: 3150 nM
Compound 4: the middle estimate sits 1.1-fold (0.02 log units) below what was measured, and the stated range covers the measured number.
By their numbers in this assay, from the lowest: compound 2; then compound 4; then compound 1. At a limit, above all of these: compound 3.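

In this assay, a five-membered aromatic ring with 2 hetero atoms is tolerated on this amide-type nitrogen: 4-(tert-butyl)-1,3-thiazol-2-yl gives a 2.2-fold lower number from compound 1 to compound 4 (0.33 log units; beyond the scatter) and so improves on 3-methoxyphenyl. It does not match 3,5-dichlorophenyl, however, with a 3.6-fold higher number from compound 2 to compound 4 (0.56 log units; beyond the scatter) as the cost of that swap. A heteroaromatic cap therefore lands between the two phenyl caps with measured numbers.

Going by these compounds, whether the thiazole ring or its tert-butyl group carries this step stays open, and a plain thiazol-2-yl or a pyridine ring would help separate them. Nothing shown here explains why these caps rank this way.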